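The compounds below may be only part of what the source reports. "The series", "measured", "known", "first", "only" and "open" are said of these compounds alone.

Compound 1 `O=C(O[C@H]1C[C@H](n2cc(F)c(=O)[nH]c2=O)O[C@@H]1COP(=O)(O)Oc1ccccc1)c1ccccc1` gives 5.1 h in an ADME assay on a cell-free system (serum, Homo sapiens) for metabolic stability, read by HPLC, tested at 2 mM; on this read-out higher numbers stand for a longer-lived compound and lower numbers for a shorter-lived compound. Compound 2 `O=C(O[C@H]1C[C@H](n2cc(F)c(=O)[nH]c2=O)O[C@@H]1COP(=O)(O)Oc1ccc2ncccc2c1)c1ccccc1` gives 16.5 h in this assay. Compound 3 `O=c1[nH]c(=O)n([C@H]2C[C@H](O)[C@@H](COP(=O)(O)Oc3ccccc3)O2)cc1F` gives 52.3 h in this assay.

Compound 3 stands highest of the three numbers in this assay; its nearest neighbour is compound 2, and compound 1 lies furthest from it. The path from compound 1 to compound 3 was a large one, a 10-fold higher number from compound 1 to compound 3 (1.01 log units; beyond the scatter).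

Compound 4 `O=c1[nH]c(=O)n([C@H]2C[C@H](O)[C@@H](COP(=O)(O)Oc3ccc4ncccc4c3)O2)cc1F` carries the change (quinolin-6-yl in place of phenyl on an oxygen). Among the measured compounds shown here, one measured step bears on it directly: the same exchange on the same oxygen was made from compound 1 to compound 2, where it brought a 3.2-fold higher number from compound 1 to compound 2 (0.51 log units; beyond the scatter), a modest step beyond the scatter. For the measured compounds named here, only that single precedent exists, and it was taken on a different partner bearing the benzoyl group, so a step of the same kind and size in the same direction is expected for compound 4 in this assay, with wide room either way. Compound 4 is therefore estimated at 140 h, within 55 h and 350 h, an expected step of a 2.7-fold higher number from compound 3 to compound 4 (0.43 log units; beyond the scatter).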

Compound 4, half-life in the Homo sapiens assay: 26.2 h
For compound 4 the middle estimate is 5.3-fold (0.73 log units) above the measured one, and the stated range ends above it.
By their numbers in the Homo sapiens assay, from the lowest: compound 1; then compounds 2, 4 and 3 (each within the scatter of the next, the first and the last beyond it).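

In the Homo sapiens assay, where compound 3 gives 52.3 h and compound 4 gives 26.2 h, quinolin-6-yl in place of phenyl gives a 2.0-fold lower number from compound 3 to compound 4 (0.30 log units; within the scatter) when the oxygen on a saturated carbon carries hydrogen instead of benzoyl, so the gain seen with benzoyl does not carry over: the same change on two cores in the Homo sapiens assay, a 3.2-fold higher number (0.51 log units; beyond the scatter) from compound 1 to compound 2 and a 2.0-fold lower number (0.30 log units; within the scatter) from compound 3 to compound 4, 6.5-fold (0.81 log units) apart, beyond the scatter of two such steps.

Hydrogen in place of benzoyl likewise gives only a 1.6-fold higher number from compound 2 to compound 4 (0.20 log units; within the scatter) when quinolin-6-yl stands on the oxygen, so the two changes do not simply add: the same change on two cores in the Homo sapiens assay, a 10-fold higher number (1.01 log units; beyond the scatter) from compound 1 to compound 3 and a 1.6-fold higher number (0.20 log units; within the scatter) from compound 2 to compound 4, 6.5-fold (0.81 log units) apart, beyond the scatter of two such steps.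

In a physicochemical assay for metabolic stability, read by HPLC, tested at 2 mM (a lower number here means that the compound disappears faster, a higher number that the compound lasts longer), the quinolin-6-yl exchange also stays within the scatter, at a 1.1-fold lower number from compound 3 to compound 4 (0.03 log units; within the scatter). In the physicochemical assay, compound 3 gives 28 h and compound 4 gives 26 h.

The compounds shown leave open whether a naphthyl group on the oxygen whose other neighbour is phosphorus would behave as quinolin-6-yl does, which would show whether the ring nitrogen matters. They also leave open whether an acetyl group in place of benzoyl would alter the quinolin-6-yl step in the same way.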